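The compounds below may be only part of what the source reports. "The series", "measured", "known", "first", "only" and "open" are said of these compounds alone.

All three measured compounds were tested in an assay on isolated protein for binding affinity to Equilibrative nucleoside transporter 1 (Homo sapiens); on this read-out lower numbers stand for stronger inhibition and higher numbers for weaker inhibition:

- compound 1 `O=[N+]([O-])c1ccc2c(c1)CCN(c1ncnc3c1ncn3[C@@H]1O[C@H](CO)[C@@H](O)[C@H]1O)C2` gives 182 nM
- compound 2 `O=[N+]([O-])c1cccc2c1CN(c1ncnc3c1nc1n3[C@@H]3O[C@H](CO1)[C@@H](O)[C@H]3O)CC2` gives 1740000 nM
- compound 3 `OC[C@H]1O[C@@H](n2cnc3c(CSc4c(F)cccc4Cl)ncnc32)[C@H](O)[C@@H]1O` gives 1510 nM

Among these three numbers compound 3 holds the second highest. Its nearest neighbour is compound 1, whose number is lower by a margin beyond the scatter; compound 2 lies far higher, also beyond the scatter.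

Compound 4 `CC(C)(C)c1ccc(SCc2ncnc3c2ncn3[C@@H]2O[C@H](CO)[C@@H](O)[C@H]2O)cc1` differs from compound 3 in one place: 4-(tert-butyl)phenyl in place of 2-chloro-6-fluorophenyl on a sulfur. For the measured compounds named here, no pair of measured compounds shows a change of this kind, so there is no measured step to lean on. The expectation is a modest move toward weaker inhibition, possibly no larger than the scatter, which is the step of a 2.0-fold higher number from compound 3 to compound 4 (0.30 log units; within the scatter). In this assay compound 4 is therefore estimated at 3000 nM, with a range from 600 nM to 15000 nM.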

Compound 4, half-maximal inhibitory concentration: 331000 nM
For compound 4 the middle estimate is 110-fold (2.04 log units) below the measured one; the measured number lies above the stated range.
By their numbers in this assay, from the lowest: compound 1; then compound 3; then compound 4; then compound 2.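

For the compounds shown here, compound 3 and compound 4 give the first measured step at this position: in this assay, 4-(tert-butyl)phenyl in place of 2-chloro-6-fluorophenyl on a sulfur gives a 220-fold higher number from compound 3 to compound 4 (2.34 log units; beyond the scatter). The aryl group on this sulfur is therefore far from interchangeable, even though the shared core stays the same and the group count under comparison still shows one aromatic ring of carbon only. Nothing available accounts for the size of this step.

The compounds shown leave open whether the step follows from losing the chlorine and fluorine or from gaining the tert-butyl group. They also leave open how a plain phenyl or a cyclohexyl group on that sulfur would read.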